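A few compounds are considered here, and "the series" means these few. Any claim that something is new, unique, unknown or untested is made for them only; others in the source may bear on it.

Working notes on the series. The parent, compound 1 `O=c1ccc2cc(OCc3cn(-c4ccccc4)nn3)ccc2o1`, carries an unsubstituted phenyl on the triazole nitrogen; in a functional assay on HL-60 cells (Homo sapiens) for cytotoxicity, read by MTT assay, with a stated time of 48 h (on this read-out higher numbers stand for weaker inhibition and lower numbers for stronger inhibition), compound 1 gives 41600 nM. Compound 2 `O=c1ccc2cc(OCc3cn(-c4ccccc4Cl)nn3)ccc2o1` was run, but in this assay compound 2 returned "not determined" (no result reported), so compound 2 stands without a number. The next member, compound 3 `O=c1ccc2cc(OCc3cn(-c4cccc([N+](=O)[O-])c4)nn3)ccc2o1`, arises from compound 2 by the change (3-nitrophenyl in place of 2-chlorophenyl on an aromatic nitrogen). With no value for compound 2, the step from compound 2 to compound 3 cannot be sized on the numbers; set beside compound 1 at 41600 nM, no shift beyond the scatter is expected in this assay either way. Compound 3 is therefore estimated at 35000 nM, within a range from 10000 nM to 100000 nM.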

Compound 3, half-maximal inhibitory concentration: 20500 nM
For compound 3 the middle estimate is 1.7-fold (0.23 log units) above the measured one; low and high end bracket the measured number.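

In this assay, within the data shown here, 3-nitrophenyl on the aromatic nitrogen in place of the unsubstituted phenyl gives a 2.0-fold lower number from compound 1 to compound 3 (0.31 log units; beyond the scatter), the first change that can be sized on numbers. The position therefore accepts a substituent on this phenyl and responds to it, though only modestly. No measured property bears on this step, so its origin stays unassigned. Going by these compounds, whether the shift belongs to the nitro group itself or to any substituent on this phenyl remains open. An amine or a carboxylic acid at the same place would help separate the two.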